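Fluoro to trifluoromethoxy on the arylidene ring

This account rests on a few compounds, and the source may have more. Where it says the series, first, only, none or still open, it means among the compounds named here.

Three compounds of the shared core have numbers in a functional assay on RAW264.7 cells (Mus musculus) for inhibition; on this read-out higher numbers stand for weaker inhibition and lower numbers for stronger inhibition. Compound 1 `O=C1/C(=C/c2ccccc2F)CCc2cc(O)ccc21` gives 1740 nM, compound 2 `O=C1/C(=C/c2cccc(O)c2)CCc2cc(O)ccc21` gives 3510 nM, and compound 3 `O=C1/C(=C/c2ccccc2F)CCc2ccc(O)cc21` gives 1350 nM. Compound 3 has the lowest of the three numbers; its gap to compound 1 lies within the scatter, so the two cannot be ordered, while its gap to compound 2 lies beyond the scatter. Compound 3 and compound 2 differ in more than one place, so what separates them cannot be assigned to a single change.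

Compound 4 `O=C1/C(=C/c2ccccc2OC(F)(F)F)CCc2ccc(O)cc21` is not yet measured in this assay. It differs from compound 3 by trifluoromethoxy in place of fluoro on an aromatic carbon, on an aromatic carbon of a six-membered aromatic ring of carbon only, ortho to a large group. Among the compounds with values here, no measured pair among the three compounds shows this same exchange, so there is no step on which to lean; the expectation rests only on compound 3 and on the size of the change.

The step from compound 3 to compound 4 is expected to be small, a 1.2-fold higher number from compound 3 to compound 4 (0.07 log units; within the scatter), in no clear direction and not beyond the scatter. Compound 4 is therefore estimated at 1600 nM, with a range from 600 nM to 4500 nM.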

Compound 4, half-maximal inhibitory concentration: 420 nM
Compound 4: the middle estimate sits 3.8-fold (0.58 log units) above what was measured; the measured number lies below the stated range.
By their numbers in this assay, from the lowest: compound 4; then compounds 3, 1 and 2 (each within the scatter of the next, the first and the last beyond it).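

In this assay, within the data shown here, trifluoromethoxy in place of fluoro on an aromatic carbon, ortho to a large group, gives a 3.2-fold lower number from compound 3 to compound 4 (0.51 log units; beyond the scatter) and this is the only step between compounds that differ in one place. Among these compounds, this place on the arylidene ring therefore accepts a substituent of five heavy atoms in place of one, and the number falls rather than rises, which the earlier compounds could not show because none of them varied this group. There is no measured information that bears on what lies behind this step, so it stands as an observation only.

A single exchange does not separate the contribution of the oxygen from that of the fluorines, and methoxy, trifluoromethyl, or a longer chain such as ethoxy at the same place would be needed to tell them apart. From the compounds shown here alone, it also remains open whether the same exchange carries over to the core of compound 1, and how an amine or a carboxylic acid would read at this place.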